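Swapping a saturated ring for an aromatic one on the chalcone tail

The compounds below may be only part of what the source reports. "The series", "measured", "known", "first", "only" and "open" are said of these compounds alone.

Of the compounds shown here, three sharing one core have been tested in a functional assay on HCT-116 cells (Homo sapiens) for antiproliferative activity, read by MTT assay, with a stated time of 24 h; a lower number here means a stronger inhibitor, a higher number a weaker inhibitor. Compound 1 `COc1ccc(C(=O)/C=C/c2ccc(F)cc2)c2c1C=CC(C)(C)O2` carries a fluoro on its terminal ring; in this assay compound 1 gives > 10000 nM, which is a limit of the assay rather than a number. Compound 2 `COc1ccc(C(=O)/C=C/c2ccc(-c3ccccc3)cc2)c2c1C=CC(C)(C)O2` carries a phenyl instead, and compound 2 also gives > 10000 nM, again a limit. Going by the values given here, compound 3 `COc1ccc(C(=O)/C=C/c2ccc(N3CCCC3)cc2)c2c1C=CC(C)(C)O2` carries a pyrrolidin-1-yl and gives 8590 nM, the only true number among the three; the other two values sit at the limit of > 10000 nM in this assay, at which 2 of the 3 values shown sit. The steps of an at least 1.1-fold lower number from compound 1 to compound 3 (0.06 log units; that floor lies within the scatter) and an at least 1.1-fold lower number from compound 2 to compound 3 (0.06 log units; that floor lies within the scatter) are each only a floor, and that floor lies within the scatter, so no real direction can be read from them.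

Compound 4 `COc1ccc(C(=O)/C=C/c2ccc(-n3ccnc3)cc2)c2c1C=CC(C)(C)O2` differs from compound 3 by 1H-imidazol-1-yl in place of pyrrolidin-1-yl on an aromatic carbon. With both reference steps unreadable beyond the scatter, no step beyond the scatter is expected, and for compound 4 the step of a 1.2-fold higher number from compound 3 to compound 4 (0.07 log units; within the scatter) is expected to be small. Compound 4 is therefore estimated at 10000 nM, within a range from 3000 nM to 30000 nM.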

Compound 4, half-maximal inhibitory concentration: > 10000 nM
Compound 4: no number, only a limit; the forecaster's own chance of this, stated with the estimate: 50%; the middle value sits exactly at the limit.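

Putting the aromatic five-membered ring of 1H-imidazol-1-yl in place of the non-aromatic ring of pyrrolidin-1-yl, at this spot para to a large group, gives an at least 1.1-fold higher number from compound 3 to compound 4 (0.06 log units; that floor lies within the scatter) in this assay, so this ring swap shows no real change in either direction. The steps from compound 1 and compound 2 to compound 4 cannot be read, since both ends of each are limits. Going by these compounds alone, compound 3 therefore remains the only compound with a true number, and a third group now joins the values stacked at one ceiling: the limit of > 10000 nM in this assay, at which 3 of the 4 values shown sit.

From the compounds shown here alone, how far the compounds at the limit really lie from compound 3 stays open. So does whether an open-chain amine such as dimethylamino, or a morpholin-4-yl ring, would give a true number at this place.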